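This account rests on a few compounds, and the source may have more. Where it says the series, first, only, none or still open, it means among the compounds named here.

Measured so far in a functional assay on A549 cells (Homo sapiens) for antiproliferative activity, read by MTT assay, with a stated time of 72 h; on this read-out lower numbers stand for stronger inhibition and higher numbers for weaker inhibition: compound 1 `CC/C=C/C(=O)Nc1cc2c(N3CCCc4ccccc43)ncnc2cc1OC` gives 5030 nM; compound 2 `CCC/C=C/C(=O)Nc1cc2c(N3CCCc4ccccc43)ncnc2cc1OC` gives 1800 nM; compound 3 `CC/C=C/C(=O)Nc1cc2c(N3CCCc4ccccc43)ncnc2cc1O[C@@H]1CCOC1` gives 14100 nM.

Compound 4 `CC(C)/C=C/C(=O)Nc1cc2c(N3CCCc4ccccc43)ncnc2cc1O[C@@H]1CCOC1` is not yet measured. Its core is that of compound 3, which differs from the core of compound 1 by oxolan-3-yl in place of methyl on an oxygen on an aromatic ring, a change that produced a 2.8-fold higher number from compound 1 to compound 3 (0.45 log units; beyond the scatter). The change from compound 3 to compound 4 is methyl in place of hydrogen on a saturated chain carbon bound to a double-bonded chain carbon and a saturated chain carbon. The same kind of change, as methyl in place of hydrogen on a saturated chain carbon, two bonds along the chain from a double-bonded chain carbon, produced a 2.8-fold lower number from compound 1 to compound 2 (0.45 log units; beyond the scatter). The two places are not identical: in compound 2 the methyl sits on a saturated chain carbon, two bonds along the chain from a double-bonded chain carbon, whereas in compound 4 it sits on a saturated chain carbon bound to a double-bonded chain carbon and a saturated chain carbon, so this is the same kind of change, not the same one. Resting on the step of a 2.8-fold lower number from compound 1 to compound 2 (0.45 log units; beyond the scatter), and allowing for the different place and core, a smaller step is expected from compound 3 to compound 4 in this assay, namely a 1.8-fold lower number from compound 3 to compound 4 (0.25 log units; within the scatter). Compound 4 is therefore estimated at 8000 nM, between 3000 nM and 20000 nM.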

Compound 4, half-maximal inhibitory concentration: 6820 nM
The estimate for compound 4 lay 1.2-fold (0.07 log units) above the measured number; measured number inside the range.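

In this assay, methyl in place of hydrogen on a saturated chain carbon bound to a double-bonded chain carbon and a saturated chain carbon gave a 2.1-fold lower number from compound 3 to compound 4 (0.32 log units; beyond the scatter). Set beside the earlier step on the core of compound 1, the change carried over to the core of compound 3 without a measurable difference in size: the same change on two cores in this assay, a 2.8-fold lower number (0.45 log units; beyond the scatter) from compound 1 to compound 2 and a 2.1-fold lower number (0.32 log units; beyond the scatter) from compound 3 to compound 4, 1.4-fold (0.13 log units) apart, within the scatter of two such steps. Going by these compounds alone, this rests on only two pairs, however, and the methyl sits in a different place in each, so it does not show that the step would hold on other cores.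

The compounds shown leave open how an amine or a longer chain at this end of the molecule would behave. They also leave open how either methyl placement would compare on a single core.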